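Shortening the chain on the amide nitrogen: compound 3

This account rests on a few compounds, and the source may have more. Where it says the series, first, only, none or still open, it means among the compounds named here.

Measured so far:
compound 1 `CC(C)(O)c1ccc(-c2cnc3c(n2)N(CCC2CCOCC2)C(=O)CN3)cn1` — 69%
compound 2 `COCCN1C(=O)CNc2ncc(-c3ccc(C(C)(C)O)nc3)nc21` — 77%

Compound 2 stands highest of the two numbers in a functional assay on the whole organism (PC-3 cells) for inhibition, with Mus musculus as the target, in a xenograft, with a stated time of 24 h, at a dose of 100 mg/kg by the oral route (a lower number here means less inhibition, a higher number more inhibition at the dose given (going by the name of the read-out)), but compound 1 lies within the scatter of it, the change being a number 8 percentage points higher from compound 1 to compound 2 (within the scatter). Compound 3 `CC(C)(O)c1ccc(-c2cnc3c(n2)N(CC2CCOCC2)C(=O)CN3)cn1` differs from compound 2 by oxan-4-yl in place of methoxymethyl on a saturated chain carbon bound to an amide-type nitrogen in a ring. For the measured compounds named here, only one step bears on this, that between compound 1 and compound 2, and it was within the scatter, so no step beyond the scatter is expected in this assay either way. For compound 3 the expected result is 72%, between 55% and 88%, an estimated step of a number 5 percentage points lower from compound 2 to compound 3 (within the scatter).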

Compound 3, a percentage reported as inhibition, in the whole organism at one dose (the size of the read-out at that dose, not a potency): 80%
Compound 3: the middle estimate sits 8 percentage points below what was measured, and the stated range covers the measured number.
By their numbers in this assay, from the lowest: compounds 1, 2 and 3 (each within the scatter of the next, the first and the last beyond it).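

In this assay, the side chain on the amide-type nitrogen accepts a ring: replacing 2-methoxyethyl with (oxan-4-yl)methyl gives (a number 3 percentage points higher from compound 2 to compound 3 (within the scatter)). Shortening the chain that carries the oxan-4-yl ring gives the first step at this position beyond the scatter, though only a modest one (a number 11 percentage points higher from compound 1 to compound 3 (beyond the scatter)). Nothing available explains either step.

On these data alone, it remains open how a dimethylamino group or a carboxylic acid at the end of this chain would read. As far as these compounds go, whether a plain methyl on the amide-type nitrogen would keep this level of inhibition is also open.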